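The source may report more compounds than this note shows. Statements on the series, on what has been measured and on what is new or still open speak of the compounds shown alone.

Compound 1 `O=C(Nc1ccc(-n2ccc3c(NC(=O)c4ccccc4)nccc32)cc1)c1ccc(Cl)c(C(F)(F)F)c1` carries a 4-chloro-3-(trifluoromethyl)phenyl amide on an unsubstituted phenyl linker, and in a functional assay on A-375 cells (Homo sapiens) for antiproliferative activity, read by MTT assay, with a stated time of 48 h, in the presence of a further agent that is not named here (on this read-out higher numbers stand for weaker inhibition and lower numbers for stronger inhibition), compound 1 gives 16.4 nM. Compound 2 `Cc1cc(NC(=O)c2cccc(C(F)(F)F)c2)ccc1-n1ccc2c(NC(=O)c3ccccc3)nccc21` has a methyl on the linker and no chloro on the amide ring. In this assay compound 2 gives only a limit, > 10000 nM. That leaves compound 2 standing at the limit of > 10000 nM in this assay, at which 1 of the 2 values shown sits. Compound 3 `Cc1cc(NC(=O)c2ccc(Cl)c(C(F)(F)F)c2)ccc1-n1ccc2c(NC(=O)c3ccccc3)nccc21` keeps the methyl-bearing linker of compound 2 and adds the chloro: chloro in place of hydrogen on an aromatic carbon, so that its amide portion matches that of compound 1. Compound 1 and compound 2 differ in two places, so their two values alone cannot be split between the methyl and the chloro. Because compound 1 reaches 16.4 nM with this chloro present, some gain is expected. The expected step is an at least 4.0-fold lower number from compound 2 to compound 3 (0.60 log units; beyond the scatter), toward stronger inhibition. For compound 3 the estimate is 2500 nM, between 300 nM and 10000 nM.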

Compound 3, half-maximal inhibitory concentration: 2700 nM
Compound 3: middle estimate off by 1.1-fold (0.03 log units), on the low side; low and high end bracket the measured number.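

Chloro in place of hydrogen, ortho to a trifluoromethyl group, now has a step of its own on the methyl-bearing linker, giving an at least 3.7-fold lower number from compound 2 to compound 3 (0.56 log units; beyond the scatter) in this assay. That step is only a bound, since compound 2 carries a limit of the assay and not a number: the limit of > 10000 nM in this assay, at which 1 of the 3 values shown sits. The methyl on the linker can also now be read alone, with the chloro held in place, and it gives a 160-fold higher number from compound 1 to compound 3 (2.22 log units; beyond the scatter), a large loss that the two earlier values could not separate from the chloro.

From the compounds shown here alone, how large the chloro step would be on the linker without the methyl remains open. So does how the amide ring would respond to a methoxy or an amine in place of the chloro, or the linker to a fluoro in place of the methyl.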